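A few compounds are considered here, and "the series" means these few. Any claim that something is new, unique, unknown or untested is made for them only; others in the source may bear on it.

Measured in an ADME assay on BJ cells (Homo sapiens) for cytotoxicity, read by CellTiter-Glo and resazurin assay, with a stated time of 72 h; on this read-out lower numbers stand for an effect already at smaller amounts and higher numbers for an effect only at larger amounts of compound:
- compound 1 `CC(C)N(Cc1cccc(OCCCCCC(=O)O)c1)C(=O)c1ccc(-c2cccc(N(C)C)c2)cc1`: > 26000 nM (a limit)
- compound 2 `CC(C)N(Cc1cccc(OCCCCCC(=O)O)c1)C(=O)c1ccc(-c2cccc3ccccc23)cc1`: < 1.3 nM (a limit)
- compound 3 `CCOc1cccc(-c2ccc(C(=O)N(Cc3cccc(OCCCCCC(=O)O)c3)C(C)C)cc2)c1`: > 20800 nM (a limit)

Compound 3 stands at > 20800 nM, which is a limit and not a number. The other two results are limits as well, so the position of compound 3 is only bounded on one side.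

Compound 4 `COc1cc(OC)cc(-c2ccc(C(=O)N(Cc3cccc(OCCCCCC(=O)O)c3)C(C)C)cc2)c1` carries 3,5-dimethoxyphenyl in place of 3-ethoxyphenyl on an aromatic carbon. The nearest measured change is a step that the two limits leave unreadable from compound 1 to compound 3, which also exchanges one substituted phenyl group for another. The two large steps, an at least 20000-fold lower number from compound 1 to compound 2 (4.30 log units; beyond the scatter) and an at least 16000-fold higher number from compound 2 to compound 3 (4.20 log units; beyond the scatter), both turn on naphthalen-1-yl, which compound 4 does not carry. Among these few compounds, the two with a substituted phenyl group give upper limits, and compound 2 goes against them.

Compound 4 keeps a substituted phenyl group, so, with a step that the two limits leave unreadable from compound 1 to compound 3 as the closest guide, no step beyond the scatter is expected in this assay, and a further limit is a likely report. The expected step is a step that the limit leaves unreadable from compound 3 to compound 4. For compound 4 the estimated value is 25000 nM, with an expected range from 8000 nM to 60000 nM.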

Compound 4, half-maximal effective concentration: > 26000 nM
Compound 4 gave a limit, no number (the forecaster's own chance of this, stated with the estimate: 80%); middle value at least 1.0-fold (0.01 log units) from the limit.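

In this assay compound 4 gives > 26000 nM, which is a limit and not a number. Exchange of naphthalen-1-yl for 3,5-dimethoxyphenyl on the aromatic carbon para to a large group gives an at least 20000-fold higher number from compound 2 to compound 4 (4.30 log units; beyond the scatter), so a third substituted phenyl group now falls with the other two, a group with two methoxy substituents included, and compound 2 remains the one compound that goes against them. The steps among compound 1, compound 3 and compound 4 cannot be read, both ends of each being limits, and compound 4 shares its reported limit with compound 1: the limit of > 26000 nM in this assay, at which 2 of the 4 values shown sit.

Open, from the compounds shown here alone, is whether the result of compound 2 belongs to naphthalen-1-yl alone, or would also appear with naphthalen-2-yl, with a phenyl group carrying no substituent, or with a substituted phenyl group bearing a simple chlorine or methyl substituent at this place. Also open, going by these compounds, is how the three substituted phenyl compounds rank among themselves, and whether the naphthalen-1-yl result survives a shorter chain ending in the carboxylic acid.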